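Chloro in place of methoxy: notes on compound 3

This account rests on a few compounds, and the source may have more. Where it says the series, first, only, none or still open, it means among the compounds named here.

Measured in a functional assay on CAL-51 cells (Homo sapiens) for inhibition, read by sulforhodamine B assay, with a stated time of 3 days; on this read-out lower numbers stand for stronger inhibition of growth and higher numbers for weaker inhibition of growth:
- compound 1 `O=C(/C=C/c1ccc(Cl)cc1)c1ccccc1`: 5850 nM
- compound 2 `COc1ccc(/C=C/C(=O)c2ccc(OCc3ccccc3)cc2)cc1`: > 50000 nM

The result for compound 2 is > 50000 nM, which is a limit of the assay and not a number. Compound 3 `O=C(/C=C/c1ccc(Cl)cc1)c1ccc(OCc2ccccc2)cc1` differs from compound 2 by chloro in place of methoxy on an aromatic carbon, para to a large group: chloro in place of methoxy on an aromatic carbon. Compound 1 also carries 4-chlorophenyl and gives 5850 nM. On that single value, a step of an at least 2.7-fold lower number from compound 2 to compound 3 (0.44 log units; beyond the scatter) is expected in this assay towards stronger inhibition of growth. For compound 3 the estimated value is 18000 nM, with an expected range of 6000 nM to 50000 nM.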

Compound 3, concentration for 50% growth inhibition: > 50000 nM
Compound 3: only a limit was reported (the forecaster's own chance of this, stated with the estimate: 30%); middle value at least 2.7-fold (0.44 log units) away from the limit.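

The change of 4-methoxyphenyl to 4-chlorophenyl cannot be read on this pair, as both results are limits of the assay: the limit of > 50000 nM in this assay, at which 2 of the 3 values shown sit.

The readable information comes from the other pair: in this assay, benzyloxy in place of hydrogen on an aromatic carbon gives an at least 8.5-fold higher number from compound 1 to compound 3 (0.93 log units; beyond the scatter). With 4-chlorophenyl held constant, weaker inhibition of growth therefore goes with the benzyloxy group.

Still open, going by these compounds, is how an amine or a carboxylic acid in place of benzyloxy would read on the core of compound 1. Also open, on these data alone, is whether 4-methoxyphenyl and 4-chlorophenyl differ once the values fall inside the readable range.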